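The compounds below may be only part of what the source reports. "The series", "measured", "known", "first", "only" and "open" are said of these compounds alone.

Compound 1 `CCOC(=O)c1c(-c2cccc(Cl)c2)[nH]c2cccc(OC)c2c1=O` in a physicochemical assay for solubility, in phosphate buffer, at pH 7.4 (on this read-out lower numbers stand for lower solubility and higher numbers for higher solubility), gives > 100000 nM, which is a limit of the assay and not a number. Compound 2 `CCOC(=O)c1c(-c2ccc(OC)cc2)[nH]c2cccc(OC)c2c1=O` gives > 100000 nM, again a limit of the assay. Compound 3 `CCOC(=O)c1c(-c2cccc(C(F)(F)F)c2)[nH]c2cc(OC)ccc2c1=O` gives 19000 nM.

Compound 2 therefore stands at the top edge of what this assay reports, and it shares that position with compound 1, since two of the three values shown sit at that edge (the limit of > 100000 nM in this assay, at which 2 of the 3 values shown sit). Compound 3 is the only one of the three with a numerical value, but it differs from compound 2 in more than one place, so no single step can be read between them. Within the data shown here, the one step between measured compounds that differ in a single place, a step that the two limits leave unreadable from compound 1 to compound 2, runs between two limits and its size cannot be read.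

Compound 4 `CCOC(=O)c1c(-c2cccc([N+](=O)[O-])c2)[nH]c2cccc(OC)c2c1=O` differs from compound 2 by 3-nitrophenyl in place of 4-methoxyphenyl on an aromatic carbon. Among the measured compounds shown here, no measured step bears directly on this change, so the expectation rests only on where compound 2 stands. The estimate for compound 4 is 50000 nM, with a range from 10000 nM to 150000 nM. This estimate amounts to an expected step of an at least 2.0-fold lower number from compound 2 to compound 4 (0.30 log units; that floor lies within the scatter), with a fair chance that the assay again reports only a limit.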

Compound 4, solubility: 49000 nM
Compound 4: the middle estimate sits 1.0-fold (0.01 log units) above what was measured; measured number inside the range.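

Among these compounds, compound 4 is the first compound with the core of compound 1 to give a number rather than a limit in this assay, so this place on the core can carry an aromatic group and still give a value the assay can report. Exchanging the whole aromatic group gives an at least 2.0-fold lower number from compound 2 to compound 4 (0.30 log units; that floor lies within the scatter), while exchanging only the substituent on the ring gives an at least 2.0-fold lower number from compound 1 to compound 4 (0.30 log units; that floor lies within the scatter). Each of these is only a floor and the true step may be larger, because the starting value of each is a limit and not a number: the limit of > 100000 nM in this assay, at which 2 of the 4 values shown sit.

As far as these compounds go, it remains open whether either step truly goes beyond the scatter, and whether the change depends on the nitro group itself or on where it sits on the ring, a question that a 4-nitrophenyl group on the same carbon would help to separate. Also open, from the compounds shown here alone, is how this read-out would respond to an amine or a carboxylic acid on that ring, or to a longer chain in place of the ethyl of the ester.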